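Changing the aryl group on the sulfonate oxygen

A few compounds are considered here, and "the series" means these few. Any claim that something is new, unique, unknown or untested is made for them only; others in the source may bear on it.

In a functional assay on M21 cells (Homo sapiens) for antiproliferative activity, read by sulforhodamine B assay, with a stated time of 48 h (on this read-out higher numbers stand for weaker inhibition and lower numbers for stronger inhibition), compound 1 `CCCN1CCN(c2ccc(S(=O)(=O)Oc3ccccc3OC)cc2)C1=O` gives > 100000 nM, which is a limit and not a number. Compound 2 `CCCCN1CCN(c2ccc(S(=O)(=O)Oc3ccccc3OC)cc2)C1=O` gives > 100000 nM, which is also a limit. For the measured compounds named here, compound 2 therefore has no exact position on the scale, and the only other value shown offers no number to compare it with.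

Compound 3 `CCCCN1CCN(c2ccc(S(=O)(=O)Oc3cc(F)cc(F)c3)cc2)C1=O` differs from compound 2 in one place: 3,5-difluorophenyl in place of 2-methoxyphenyl on an oxygen. Here, 3,5-difluorophenyl stands in place of 2-methoxyphenyl on an oxygen.

Going by the values given here, the one measured step, a step that the two limits leave unreadable from compound 1 to compound 2, concerns the chain and not this oxygen, and it has no readable size to carry over. The remaining evidence is the limit of > 100000 nM in this assay, at which 2 of the 2 values shown sit. Among the compounds with values here, no measured step therefore gives a size for this change, so compound 3 is expected to stay at or close to that limit in this assay. Any readable shift would have to be toward stronger inhibition.

The estimate implies an at least 1.4-fold lower number from compound 2 to compound 3 (0.15 log units; that floor lies within the scatter), an expected step of uncertain size. For compound 3, the estimated value is 70000 nM, with an expected range from 15000 nM to 100000 nM.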

Compound 3, half-maximal inhibitory concentration: > 100000 nM
Compound 3: a limit, no number (the forecaster's own chance of this, stated with the estimate: 60%); at least 1.4-fold (0.15 log units) between middle value and limit.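

For the compounds shown here, compound 2 and compound 3 both end at a limit and not at a number in this assay, so no step between them can be read. All the evidence comes down to one shared limit: the limit of > 100000 nM in this assay, at which 3 of the 3 values shown sit. The compounds shown leave open whether any change to the chain or to the aryl group on the sulfonate oxygen would give a readable number in this assay at all.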